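This account rests on a few compounds, and the source may have more. Where it says the series, first, only, none or still open, it means among the compounds named here.

Of the compounds shown here, three built on one shared core have been tested in a functional assay on U-373MG ATCC cells (Homo sapiens) for inhibition, read by MTT assay, with a stated time of 72 h; on this read-out lower numbers stand for stronger inhibition of growth and higher numbers for weaker inhibition of growth. Compound 1 `Clc1ccc(Sc2c(-c3ccc(Cl)cc3)[nH]c3ccc(Cl)cc23)cc1` gives 28000 nM in this assay. Compound 2 `CCOC(=O)C1CCN(C(=S)Sc2c(-c3ccc(Br)cc3)[nH]c3ccc(C)cc23)CC1` gives 68000 nM in this assay. Compound 3 `CCOC(=O)C1CCN(C(=S)Sc2c(-c3ccc(Br)cc3)n(C)c3ccccc23)CC1` reaches only a limit of this assay, > 100000 nM, so no number is known for it and it stands at the limit of > 100000 nM in this assay, at which 1 of the 3 values shown sits. Compound 1 and compound 2 both carry a hydrogen on the ring nitrogen of the shared core and both gave measurable numbers; compound 3, which carries a methyl there, did not.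

Compound 4 `CCOC(=O)C1CCN(C(=S)Sc2c(-c3ccc(Br)cc3)[nH]c3ccccc23)CC1` has not yet been measured. It differs from compound 3 by hydrogen in place of methyl on an aromatic nitrogen. Going by the values given here, no measured pair shows this exact change on its own, so what is expected must come from the compounds already seen. Compound 4 is expected to give 70000 nM in this assay, with a range from 30000 nM to 150000 nM. This expectation rests on compound 2, which also carries a hydrogen on that nitrogen and gives 68000 nM. The step from compound 3 to compound 4 that this estimate implies, an at least 1.4-fold lower number from compound 3 to compound 4 (0.15 log units; that floor lies within the scatter), is expected to run toward stronger inhibition of growth, though with a fair chance that compound 4 too will be reported only as a limit.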

Compound 4, concentration for 50% growth inhibition: 35000 nM
Compound 4: the middle estimate sits 2.0-fold (0.30 log units) above what was measured, within the range that was stated.
By their numbers in this assay, from the lowest: compounds 1, 4 and 2 (each within the scatter of the next, the first and the last beyond it). At a limit, above all of these: compound 3.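

In this assay, putting hydrogen in place of methyl on the aromatic nitrogen gives an at least 2.8-fold lower number from compound 3 to compound 4 (0.45 log units; beyond the scatter), the first direct view of this single change with nothing else altered in the molecule. As far as these compounds go, the true size of the step stays unknown, as only one end of it is a number and compound 3 stands at a limit of the assay: the limit of > 100000 nM in this assay, at which 1 of the 4 values shown sits. The other new pair, with hydrogen in place of methyl on an aromatic carbon, gives a 1.9-fold lower number from compound 2 to compound 4 (0.29 log units; within the scatter), so that change cannot be told from repeat scatter, while the change on the nitrogen, on this single pair, can.

From the compounds shown here alone, only hydrogen and methyl are seen on this nitrogen, so it remains open whether a longer chain such as ethyl, or an acetyl group, would behave like the methyl of compound 3. It also remains open whether the same change would have the same effect with the simpler 4-chlorophenyl sulfur group of compound 1, which has no methyl-bearing partner among these compounds.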